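A Benzoyl Group Replaces the Nitrile: Expected Growth Inhibition

The source may report more compounds than this note shows. Statements on the series, on what has been measured and on what is new or still open speak of the compounds shown alone.

Of the compounds shown here, two of a shared core have been measured in a functional assay on HL-60 cells (Homo sapiens) for inhibition, read by MTT assay, with a stated time of 72 h, tested at 30 uM; a lower number here means less inhibition of growth, a higher number more inhibition of growth at the concentration tested. Compound 1 `C=CCc1ccc(OCc2cn(-c3ccc(C#N)cc3)nn2)c(O)c1` gives 20.8%. Compound 2 `C=CCc1ccc(OCc2cn(-c3ccccc3Cl)nn2)c(O)c1`, which carries 2-chlorophenyl in place of 4-cyanophenyl on the aromatic nitrogen, gives 38.7%. Within the data shown here, compound 1 thus stands lowest of the two numbers, and the only step seen so far, a number 17.9 percentage points higher from compound 1 to compound 2 (beyond the scatter), runs upward from it.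

Compound 3 `C=CCc1ccc(OCc2cn(-c3ccc(C(=O)c4ccccc4)cc3)nn2)c(O)c1` has not been measured. It differs from compound 1 in that (benzoyl in place of cyano on an aromatic carbon). Among the measured compounds shown here, no measured step covers this exchange: the step from compound 1 to compound 2 replaces the whole substituent on the aromatic nitrogen, whereas compound 3 keeps the six-membered aromatic ring of carbon only and alters just the group para to the large group. That step shows that what sits on the aromatic nitrogen can move the reading by a modest amount, and nothing more can be drawn from it. For compound 3 a modest rise is expected, a number 9.2 percentage points higher from compound 1 to compound 3 (within the scatter), with wide uncertainty. The estimate for compound 3 in this assay is 30%, expected to fall between 10% and 55%.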

Compound 3, percent growth inhibition at one concentration: 38.3%
Compound 3: middle estimate off by 8.3 percentage points, on the low side, and the stated range covers the measured number.
By their numbers in this assay, from the lowest: compound 1; then compounds 3 and 2 (each within the scatter of the next).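

Compound 1 is now set apart from both other compounds. The exchange of cyano for benzoyl on an aromatic carbon, para to a large group, leaves the rest of compound 1 untouched and still gives a number 17.5 percentage points higher from compound 1 to compound 3 (beyond the scatter) in this assay, so the earlier finding that replacing the whole substituent on the aromatic nitrogen can move the reading now has a narrower counterpart: a change at this one position is enough, and it is a modest step beyond the scatter. The position also accepts a far larger group than cyano without a loss of growth inhibition at the concentration tested, since benzoyl brings more heavy atoms and a six-membered aromatic ring of carbon only, while the counts of hydrogen-bond donors and acceptors stay the same. Nothing available explains why the reading moves with this exchange.

From the compounds shown here alone, what remains open is whether the added ring or the carbonyl goes with the higher reading, a question that a plain phenyl or a benzyl group on the same carbon would address. Going by these compounds, it is equally open how this position responds to an amine, a carboxylic acid or a longer chain.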